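The source may hold more compounds than are shown below. What is called first, only, known or untested is meant among the compounds shown, and "the series" means these compounds.

Measured so far in a functional assay on HEK293 cells for positive allosteric modulation of metabotropic glutamate receptor 5 (Homo sapiens), read by calcium flux; a lower number here means a smaller maximal response, a higher number a larger maximal response:

compound 1, `O=C(C1CCC1)N1CCCn2nc(COc3ccccc3)cc21`, 41%
compound 2, `O=C(c1cccc(F)c1)N1CCCn2nc(COc3ccccc3)cc21`, 61%
compound 3, `O=C(c1ccncc1)N1CCCn2nc(COc3ccccc3)cc21`, 51%

Compound 3 stands second highest of the three numbers. Its nearest neighbour is compound 1, a number 10 percentage points higher from compound 1 to compound 3 (within the scatter); its furthest is compound 2, a number 10 percentage points lower from compound 2 to compound 3 (within the scatter). Neither gap separates compound 3 from the other two.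

Compound 4 is `O=C(c1ccco1)N1CCCn2nc(COc3ccccc3)cc21`. It differs from compound 3 in one place: furan-2-yl in place of pyridin-4-yl on a carbonyl carbon

For the measured compounds named here, two steps bear on this change, both at the carbonyl carbon. Going by the values given here, the aromatic groups in compounds 2 and 3 stand together, a number 10 percentage points lower from compound 2 to compound 3 (within the scatter), while the only step beyond the scatter, a number 20 percentage points higher from compound 1 to compound 2 (beyond the scatter), is from the non-aromatic cyclobutyl to an aromatic group. Compound 4 keeps an aromatic ring on the carbonyl carbon, so compound 4 is expected to stay with compounds 2 and 3 rather than move toward compound 1. Compound 4 is expected to give a number 4 percentage points higher from compound 3 to compound 4 (within the scatter). The estimate for compound 4 is 55%, with a range from 40% to 70%.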

Compound 4, largest response reached (reported as percent of maximum), in percent of the reference or control that the assay uses: < 15%
Compound 4 ended at the assay's limit; the forecaster's own chance of this, stated with the estimate: 2%; middle value at least 40 percentage points from the limit.
By their numbers in this assay, from the lowest: compounds 1, 3 and 2 (each within the scatter of the next, the first and the last beyond it). At a limit, below all of these: compound 4.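

In this assay compound 4 gives < 15%, which is a limit of the assay and not a number: the limit of < 15% in this assay, at which 1 of the 4 values shown sits.

An aromatic ring on the carbonyl carbon therefore does not by itself keep the maximal response, as the furan-2-yl group stands well apart from the pyridin-4-yl and 3-fluorophenyl groups, with a number at least 36 percentage points lower from compound 3 to compound 4 (beyond the scatter) and a number at least 46 percentage points lower from compound 2 to compound 4 (beyond the scatter). The non-aromatic cyclobutyl group also gives more than the furan-2-yl group, with a number at least 26 percentage points lower from compound 1 to compound 4 (beyond the scatter), so compound 4 goes against any split of this position into aromatic and non-aromatic groups, and the position proves sensitive to a change of one aromatic ring for another.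

The compounds shown leave open whether the drop goes with the five-membered ring, with its oxygen or with where that oxygen sits; thiophen-2-yl and furan-3-yl on the same carbonyl carbon would separate these readings. Going by these compounds, how far compound 4 lies past the limit also stays open, so its steps give only a minimum size.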